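This account rests on a few compounds, and the source may have more. Where it says the series, first, only, none or still open, it means among the compounds named here.

Measured compounds:
compound 1, `C=CCOC(=O)Nc1ccc([Se]C#N)cc1`: 27000 nM
compound 2, `CCCOC(=O)Nc1ccc([Se]C#N)cc1`: 28900 nM
compound 3, `N#C[Se]c1ccc(NC(=O)OCc2ccccc2)cc1`: 27600 nM

All readings come from a functional assay on HTB-54 cells (Homo sapiens) for cytotoxicity, read by MTT assay, with a stated time of 72 h; on this read-out higher numbers stand for weaker inhibition of growth and lower numbers for stronger inhibition of growth. The three compounds share a core and differ only in the group on a saturated chain carbon bound to an oxygen next to a carbonyl group. Compound 3 stands second highest of the three numbers; its nearest neighbour is compound 1, with a 1.0-fold higher number from compound 1 to compound 3 (0.01 log units; within the scatter), and its furthest is compound 2, with a 1.0-fold lower number from compound 2 to compound 3 (0.02 log units; within the scatter). Both steps lie within the scatter, as does a 1.1-fold higher number from compound 1 to compound 2 (0.03 log units; within the scatter), so on these numbers nothing separates the three.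

Compound 4, `CCOC(=O)Nc1ccc([Se]C#N)cc1`, has not yet been measured in this assay. It differs from compound 3 as follows: methyl in place of phenyl on a saturated chain carbon bound to an oxygen next to a carbonyl group. Within the data shown here, the steps that bear on this change are those at the same place: vinyl to phenyl, a 1.0-fold higher number from compound 1 to compound 3 (0.01 log units; within the scatter), and ethyl to phenyl, a 1.0-fold lower number from compound 2 to compound 3 (0.02 log units; within the scatter). Each was within the scatter, and no group tried at this place has moved the number. Methyl has not been tested, so the expectation rests only on these three compounds. Compound 4 is therefore expected to stay at the level of the series, with a 1.0-fold higher number from compound 3 to compound 4 (0.01 log units; within the scatter) not beyond the scatter. The estimate for compound 4 in this assay is 28000 nM, with a range from 14000 nM to 56000 nM.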

Compound 4, concentration for 50% growth inhibition: 24900 nM
Compound 4: middle estimate off by 1.1-fold (0.05 log units), on the high side; measured number inside the range.
By their numbers in this assay, from the lowest: compounds 4, 1, 3 and 2 (each within the scatter of the next).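

In this assay the change from phenyl to methyl removes the six-membered aromatic ring of carbon only from this place, yet the number stays within the scatter (a 1.1-fold lower number from compound 3 to compound 4 (0.04 log units; within the scatter)), so at this place the series does not depend on that ring. The other two comparisons agree: hydrogen in place of methyl on the saturated chain carbon, two bonds along the chain from the oxygen, gives a 1.2-fold lower number from compound 2 to compound 4 (0.06 log units; within the scatter), and methyl in place of vinyl gives a 1.1-fold lower number from compound 1 to compound 4 (0.04 log units; within the scatter), both also within the scatter, so methyl, ethyl, vinyl and phenyl on the saturated chain carbon bound to the oxygen cannot be told apart on these numbers. No measurement at hand offers an explanation for this flat result.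

On these data alone, all four groups are plain hydrocarbons with no hydrogen-bond donors or acceptors and no net charge, so it remains open whether an amine, a carboxylic acid or a longer chain at this place would move the number beyond the scatter. The compounds also leave open whether this flat level would hold with a change elsewhere on the shared core, since every comparison here is confined to one place.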